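Aroyl for acetyl on the hydroxamate of compound 2

The source may hold more compounds than are shown below. What is called first, only, known or untested is meant among the compounds shown, and "the series" means these compounds.

Three hydroxamic acids share the N-hydroxy acetamide head on a one-carbon-branched benzylic position. Compound 1 `CC(=O)N(O)C(C)c1ccc(OCCc2ccccc2)cc1` gives 410 nM in an assay on RBL cells for inhibition of Polyunsaturated fatty acid 5-lipoxygenase (Rattus norvegicus); on this read-out higher numbers stand for weaker inhibition and lower numbers for stronger inhibition. Compound 2 `CC(=O)N(O)C(C)c1ccc2oc(-c3ccccc3)cc2c1` gives 490 nM in this assay, and compound 3 `CCCCCCCCCCc1cc2cc(C(C)N(O)C(C)=O)ccc2o1` gives 410 nM. Compound 2 holds the highest of the three numbers, yet its gap to compound 1 and its gap to compound 3 both fall inside the usual scatter, so the three values read as one level rather than a ranking.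

Compound 4 `COc1ccc(C(=O)N(O)C(C)c2ccc3oc(-c4ccccc4)cc3c2)cc1OC` keeps the core of compound 2 and changes only the acyl group: 3,4-dimethoxyphenyl in place of methyl on a carbonyl carbon. Within the data shown here, no measured pair in the set maps this kind of change, so the expectation rests on the head group being altered on every compound of the series at once, with no internal reference. The expected outcome for compound 4 is a step from compound 2 of modest size toward a weaker number, a 1.8-fold higher number from compound 2 to compound 4 (0.26 log units; within the scatter), though a result within the scatter cannot be excluded. The estimated value for compound 4 in this assay is 900 nM, with a range from 200 nM to 4000 nM.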

Compound 4, half-maximal inhibitory concentration: 200 nM
Estimate against measurement, compound 4: 4.5-fold (0.65 log units) above; measured number inside the range.
By their numbers in this assay, from the lowest: compound 4; then compounds 1, 3 and 2 (each within the scatter of the next).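

The carbonyl carbon of the hydroxamate, occupied by methyl in compounds 1, 2 and 3, proves able to carry a much larger acyl group without loss of inhibition. In this assay, among these compounds, placing 3,4-dimethoxyphenyl there in place of methyl gives a 2.5-fold lower number from compound 2 to compound 4 (0.39 log units; beyond the scatter), so this change moves the read-out towards stronger inhibition, and this is the first single-place step to show that the acyl position affects the number. No available measurement bears on why the number falls.

The compounds shown leave open which part of the new group matters, since the aromatic ring and the two methoxy groups enter together; an unsubstituted phenyl, a single methoxy group, or a cyclohexyl or longer alkyl chain on the same carbonyl carbon would begin to separate these parts. Going by these compounds, it also remains open whether the same acyl exchange would carry over to the cores of compound 1 and compound 3, where the group on the far side of the molecule differs.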